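The source may report more compounds than this note shows. Statements on the series, on what has been measured and on what is new or still open speak of the compounds shown alone.

Compound 1 `COc1ccc(-c2[nH]c3ccccc3c2/C=C(\C#N)S(=O)(=O)c2ccccc2)cc1` gives 254 nM in a functional assay on COLO 205 cells (Homo sapiens) for inhibition, read by sulforhodamine B assay, with a stated time of 48 h; on this read-out lower numbers stand for stronger inhibition of growth and higher numbers for weaker inhibition of growth.
Compound 2 `COc1ccc(-c2[nH]c3ccc(OC)cc3c2/C=C(\C#N)S(=O)(=O)c2ccccc2)cc1` gives 396 nM in this assay.

Compound 2 carries the higher of the two numbers, but the step of a 1.6-fold higher number from compound 1 to compound 2 (0.19 log units; within the scatter) stays within the scatter, so the two measured compounds cannot be told apart on growth inhibition. Compound 3 `COc1ccc2[nH]c(-c3ccccc3)c(/C=C(\C#N)S(=O)(=O)c3ccccc3)c2c1` is compound 2 with hydrogen in place of methoxy on an aromatic carbon. Among the compounds with values here, the one measured step, a 1.6-fold higher number from compound 1 to compound 2 (0.19 log units; within the scatter), concerns a methoxy at a different place, added to the shared core rather than removed from the ring where this change sits; it moved the number only a little. Within the data shown here, no measured step touches the methoxy that leaves here. Among the measured compounds shown here, with only that indirect guide, the number for compound 3 is expected to remain close to that of compound 2, with a step of a 1.0-fold lower number from compound 2 to compound 3 (0.02 log units; within the scatter) and no firm direction. Compound 3 is therefore estimated at 380 nM, within a range from 150 nM to 1000 nM.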

Compound 3, concentration for 50% growth inhibition: 7400 nM
For compound 3 the middle estimate is 19-fold (1.29 log units) below the measured one; measured number outside the range, above it.
By their numbers in this assay, from the lowest: compounds 1 and 2 (each within the scatter of the next); then compound 3.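

Changing 4-methoxyphenyl to phenyl produces a large loss of growth inhibition in this assay (a 19-fold higher number from compound 2 to compound 3 (1.27 log units; beyond the scatter)), so the methoxy at this place, para to a large group, makes a clear difference. The other methoxy, on the shared core, showed no such effect (a 1.6-fold higher number from compound 1 to compound 2 (0.19 log units; within the scatter)), so the two methoxy groups cannot be treated as interchangeable in this series. No measurement available here explains why removing this methoxy has so large an effect.

The compounds shown leave open whether this place needs methoxy specifically or would also tolerate another group, such as ethoxy, hydroxy or fluorine. As far as these compounds go, it also remains open whether the same loss would appear if this methoxy were removed from compound 1, which lacks the methoxy on the shared core.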